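The source may report more compounds than this note shows. Statements on the series, on what has been measured and on what is new or still open speak of the compounds shown alone.

Values in a functional assay on Urethra for agonist activity at Alpha-1A adrenergic receptor (Oryctolagus cuniculus) (a lower number here means a less potent compound, a higher number a more potent compound, by a factor of ten per unit of this negative logarithm), for the measured members of the series:

compound 1 `COc1ccc(NS(C)(=O)=O)c2c1C(c1c[nH]cn1)CCC2` gives 4.81
compound 2 `Cc1ccc(NS(C)(=O)=O)c2c1C(c1c[nH]cn1)CCC2` gives 4.4
compound 3 `CS(=O)(=O)Nc1ccc(F)c2c1CCCC2c1c[nH]cn1` gives 5.31

Compound 3 stands highest of the three in this assay: the step of a number 0.50 log units higher from compound 1 to compound 3 (beyond the scatter) and the step of a number 0.91 log units higher from compound 2 to compound 3 (beyond the scatter) both lie beyond the scatter, as does the step of a number 0.41 log units lower from compound 1 to compound 2 (beyond the scatter). All three measured steps are exchanges at the same aromatic carbon, and each one moved the number by a modest amount.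

Compound 4 `CS(=O)(=O)Nc1ccc(Cl)c2c1CCCC2c1c[nH]cn1` differs from compound 3 by chloro in place of fluoro on an aromatic carbon. Among the measured compounds shown here, no measured step exchanges one halogen for another at this position; the steps known here show only that methoxy, methyl and fluoro at this carbon give numbers spread over a modest span, with fluoro the highest. For compound 4 a number near that of compound 3 is therefore expected, with no step beyond the scatter in this assay assumed, the estimated step being a number 0.01 log units lower from compound 3 to compound 4 (within the scatter). The estimate for compound 4 is 5.3, with a range from 4.7 to 5.9.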

Compound 4, negative logarithm of the half-maximal effective concentration: 4.35
The estimate for compound 4 lay 0.95 log units above the measured number, outside the stated range (below it).
By their numbers in this assay, from the lowest: compounds 4 and 2 (each within the scatter of the next); then compound 1; then compound 3.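

In this assay, among the compounds shown here, this aromatic carbon para to the methanesulfonamido group does not treat the two halogens alike: a number 0.96 log units lower from compound 3 to compound 4 (beyond the scatter), the largest step seen at this position so far. Chloro cannot be told apart from methyl here, a number 0.05 log units lower from compound 2 to compound 4 (within the scatter), and it also falls short of methoxy, a number 0.46 log units lower from compound 1 to compound 4 (beyond the scatter), so among these four compounds the highest number goes with fluoro alone and not with halogens as a class, compound 4 being the one that goes against such a class reading. No evidence is available on what lies behind the gap between fluoro and chloro.

Where bromo, a nitrile or an amine would fall at this carbon remains open. Also open, going by these compounds, is whether the same order of groups would hold with a longer chain in place of the methanesulfonamido group.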